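This account rests on a few compounds, and the source may have more. Where it says the series, first, only, none or still open, it means among the compounds named here.

Compound 1 `O=C(O)c1cn(Cc2ccc(O)cc2)c2ccccc2c1=O` carries a carboxylic acid on the shared core and a 4-hydroxyphenyl group. Compound 1 gives 14.6% in a functional assay, tested at 10 uM; on this read-out lower numbers stand for a weaker effect and higher numbers for a stronger effect at the one concentration tested. Compound 2 `O=C(NO)c1cn(Cc2ccc(Cl)cc2)c2ccccc2c1=O` and compound 3 `O=C(NO)c1cn(Cc2ccc(Br)cc2)c2ccccc2c1=O` carry a hydroxamic acid instead of that carboxylic acid. In this assay compound 2 stands at "not determined" (no result reported). In this assay compound 3 stands at "not determined" (no result reported), so compound 3 is without any number and nothing can be read from it. Compound 4 `O=C(NO)c1cn(Cc2ccc(O)cc2)c2ccccc2c1=O` differs from compound 3 in one place: hydroxy in place of bromo on an aromatic carbon. Within the data shown here, since no step between measured compounds exists, no change of any size or direction in this assay can be expected on that basis. Compound 1 shares the 4-hydroxyphenyl group with compound 4, and compound 1 gives 14.6% in this assay. Compound 4 is estimated at about 30%, expected to fall between 5% and 75%.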

Compound 4, a percentage reported as activity, at one concentration (the size of the read-out at that concentration, not a potency): 32.3%
Compound 4: the middle estimate sits 2.3 percentage points below what was measured, within the range that was stated.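

With the 4-hydroxyphenyl group held fixed, the hydroxamic acid can now be set against the carboxylic acid on the shared core. In this assay this gives a number 17.7 percentage points higher from compound 1 to compound 4 (beyond the scatter) for that single change. The change from 4-bromophenyl to 4-hydroxyphenyl cannot be read, as compound 3 has no number, and no measurement at hand explains the rise. Going by these compounds, it remains open whether the hydroxamic acid is the best group here, or whether a primary amide or a methyl ester would do as well. An amine in place of the hydroxy on the aromatic ring is also untested in the compounds shown.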